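Notes on a fluorophenyl positional isomer

This account rests on a few compounds, and the source may have more. Where it says the series, first, only, none or still open, it means among the compounds named here.

Going by the values given here, in a functional assay on Huh-7 cells (Homo sapiens) for inhibition, read by sulforhodamine B assay (on this read-out higher numbers stand for weaker inhibition and lower numbers for stronger inhibition), compound 2 `C#CC(=O)N1C(c2ccccc2F)SC[C@@H]1C(=O)OCC` gives 1700 nM, the highest of the three numbers so far. Compound 3 `C#CC(=O)N1C(CC(C)CC(C)(C)C)SC[C@@H]1C(=O)OCC` gives 1600 nM, which lies within the scatter of compound 2. Among the compounds with values here, compound 1 `C#CC(=O)N1C(C(C)CCC)SC[C@@H]1C(=O)OCC` gives 600 nM, and the only single-change step among the measured compounds is a 2.8-fold higher number from compound 1 to compound 2 (0.45 log units; beyond the scatter), a modest change on replacing an alkyl chain with the aryl group.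

Compound 4 `C#CC(=O)N1C(c2ccc(F)cc2)SC[C@@H]1C(=O)OCC` differs from compound 2 by 4-fluorophenyl in place of 2-fluorophenyl on a saturated ring carbon. Within the data shown here, no measured step bears directly on this kind of change: the one step available compares an alkyl with an aryl substituent, not two aryl isomers, and the whole series so far spans only a narrow range. With nothing pointing one way or the other, the step from compound 2 to compound 4 is expected to stay within the scatter, and a 1.1-fold lower number from compound 2 to compound 4 (0.05 log units; within the scatter) is the estimated outcome. For compound 4 in this assay the expected value is 1500 nM, with a range from 600 nM to 4000 nM.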

Compound 4, half-maximal inhibitory concentration: 700 nM
For compound 4 the middle estimate is 2.1-fold (0.33 log units) above the measured one; the range from low to high includes it.
By their numbers in this assay, from the lowest: compounds 1 and 4 (each within the scatter of the next); then compounds 3 and 2 (each within the scatter of the next).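

At this saturated ring carbon, the place of the fluorine on the aryl group counts in this assay: with the same atoms joined differently, there is a 2.4-fold lower number from compound 2 to compound 4 (0.39 log units; beyond the scatter), so 2-fluorophenyl and 4-fluorophenyl are not interchangeable here. The earlier step, a 2.8-fold higher number from compound 1 to compound 2 (0.45 log units; beyond the scatter), therefore does not describe aryl groups in general, since a 1.2-fold higher number from compound 1 to compound 4 (0.07 log units; within the scatter) leaves 4-fluorophenyl within the scatter of 1-methylbutyl. Nothing available explains the gap between the two fluorophenyl isomers.

Still open, on these data alone, is whether the fluorine itself is needed, which a plain phenyl or a chlorophenyl at this carbon would address. The compounds shown also leave open how an aryl group carrying an amine or a carboxylic acid would read out in this series.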